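From Ester to Propyl Amide on a Shared Core

The source may report more compounds than this note shows. Statements on the series, on what has been measured and on what is new or still open speak of the compounds shown alone.

In a functional assay on cells (Platelet, Homo sapiens) for inhibition (on this read-out higher numbers stand for weaker inhibition and lower numbers for stronger inhibition), compound 1 (`CCOC(=O)c1cccc(-c2n[nH]c3ccccc23)c1`) gives > 10000 nM as a limit of the assay. Compound 2 (`CCCCn1nc(-c2ccc(C(=O)OCC)cc2)c2ccccc21`) likewise gives only a limit, > 10000 nM, and no number. Compound 3 (`COC(=O)c1ccc(-c2nn(Cc3ccccc3)c3ccccc23)cc1`) also reaches only a limit, > 10000 nM, in the same read-out. Compound 3 thus stands with the other two on the limit of > 10000 nM in this assay, at which 3 of the 3 values shown sit, and cannot be ranked against them.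

Compound 4 (`CCCNC(=O)c1ccc(-c2nn(Cc3ccccc3)c3ccccc23)cc1`) keeps the core of compound 3 but has propylamino in place of methoxy on a carbonyl carbon, so methoxycarbonyl becomes propylcarbamoyl (propylamino in place of methoxy on a carbonyl carbon). Among the measured compounds shown here, no measured pair shows what this exchange does, and no measured compound offers a number to start from. In this assay the expected change is small and, if it appears at all, leans toward stronger inhibition, and the estimated step is an at least 1.1-fold lower number from compound 3 to compound 4 (0.04 log units; that floor lies within the scatter) on that view. Another limit would be no surprise. The estimate for compound 4 is 9000 nM, with the expected range running from 2000 nM to 30000 nM.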

Compound 4, half-maximal inhibitory concentration: > 10000 nM
Compound 4 gave a limit, no number; the forecaster's own chance of this, stated with the estimate: 60%; at least 1.1-fold (0.04 log units) between middle value and limit.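

Compound 3 and compound 4 both give only a limit in this assay, so no step can be read between them. The compounds shown leave open how far any change on the shared core moves inhibition, for they offer no number to compare: the limit of > 10000 nM in this assay, at which 4 of the 4 values shown sit.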